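Working notes: anilino swap applied to the bromo analogue

The compounds below may be only part of what the source reports. "The series", "measured", "known", "first", "only" and "open" are said of these compounds alone.

Values in a functional assay on MGC-803 cells (Homo sapiens) for inhibition, read by MTT assay, with a stated time of 72 h (a lower number here means a stronger inhibitor, a higher number a weaker inhibitor), so far:
- compound 2 `Cc1ccc(Nc2nc(SCc3cn(CC(=O)NC(=O)Nc4ccccn4)nn3)nc(-c3ccc(C(C)C)cc3)c2C#N)cc1` gives 3360 nM
- compound 3 `Cc1ccc(Nc2nc(SCc3cn(CC(=O)NC(=O)Nc4ccccn4)nn3)nc(-c3ccc(Br)cc3)c2C#N)cc1` gives 13900 nM
- compound 1 `CC(C)c1ccc(-c2nc(SCc3cn(CC(=O)NC(=O)Nc4ccccn4)nn3)nc(Nc3cccc(C(F)(F)F)c3)c2C#N)cc1` reaches only the limit of this assay, > 64000 nM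

The shared core is kept throughout. Compound 2 and compound 3 differ by bromo in place of isopropyl on an aromatic carbon; this gives a 4.1-fold higher number from compound 2 to compound 3 (0.62 log units; beyond the scatter). Compound 2 and compound 1 differ by 3-(trifluoromethyl)phenyl in place of 4-methylphenyl on a nitrogen on an aromatic ring; this gives an at least 19-fold higher number from compound 2 to compound 1 (1.27 log units; beyond the scatter), with compound 1 sitting at the limit of > 64000 nM in this assay, at which 1 of the 3 values shown sits.

Compound 4 `N#Cc1c(Nc2cccc(C(F)(F)F)c2)nc(SCc2cn(CC(=O)NC(=O)Nc3ccccn3)nn2)nc1-c1ccc(Br)cc1` is not yet measured. It differs from compound 3 by 3-(trifluoromethyl)phenyl in place of 4-methylphenyl on a nitrogen on an aromatic ring, the same change as from compound 2 to compound 1, at an identical place. Starting from compound 3, which already gives 13900 nM, a step of the size seen in an at least 19-fold higher number from compound 2 to compound 1 (1.27 log units; beyond the scatter) is expected, so compound 4 is expected to show an 11-fold higher number from compound 3 to compound 4 (1.03 log units; beyond the scatter). Compound 4 is therefore estimated at 150000 nM, between 40000 nM and 500000 nM, and most likely this assay will report only a limit for compound 4.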

Compound 4, half-maximal inhibitory concentration: 3600 nM
Beside the measured number, compound 4's estimate is 42-fold (1.62 log units) above it; measured number outside the range, below it.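

In this assay, the swap to 3-(trifluoromethyl)phenyl does not carry from one core to the other, giving a 3.9-fold lower number from compound 3 to compound 4 (0.59 log units; beyond the scatter), opposite in direction to the earlier step: the same change on two cores in this assay, an at least 19-fold higher number (1.27 log units; beyond the scatter) from compound 2 to compound 1 and a 3.9-fold lower number (0.59 log units; beyond the scatter) from compound 3 to compound 4, at least 73-fold (1.86 log units) apart, beyond the scatter of two such steps. Read the other way, bromo in place of isopropyl gives an at least 17-fold lower number from compound 1 to compound 4 (1.24 log units; beyond the scatter), again opposite to the earlier step: the same change on two cores in this assay, a 4.1-fold higher number (0.62 log units; beyond the scatter) from compound 2 to compound 3 and an at least 17-fold lower number (1.24 log units; beyond the scatter) from compound 1 to compound 4, at least 73-fold (1.86 log units) apart, beyond the scatter of two such steps. Compound 1 gives > 64000 nM, which is a limit, and the four compounds show that the two changes do not act independently, without showing why or how far this reaches beyond them.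

Still open, as far as these compounds go, is how the swap on the nitrogen behaves with a third group on the aromatic carbon, such as chloro or methoxy. Also open, from the compounds shown here alone, is how an unsubstituted phenyl on the nitrogen would read.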